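Aryl hydrazone variation on a shared core

This account rests on a few compounds, and the source may have more. Where it says the series, first, only, none or still open, it means among the compounds named here.

Measured so far in a functional assay on HepG2 cells (Homo sapiens) for inhibition, read by MTT assay, with a stated time of 72 h; a higher number here means a weaker inhibitor, a lower number a stronger inhibitor:
compound 1 `CN(C(=O)NC(=O)c1ccccc1F)c1nc(C(F)(F)F)c(C(=O)N/N=C/c2cc(C(F)(F)F)cc(C(F)(F)F)c2)s1`: 4.47 ug/mL
compound 2 `CN(C(=O)NC(=O)c1ccccc1F)c1nc(C(F)(F)F)c(C(=O)N/N=C/c2ccccc2C(F)(F)F)s1`: 5.39 ug/mL

Compound 2 holds the higher of the two numbers in this assay; its nearest neighbour is compound 1, whose number is lower by a margin that stays within the scatter, so no order between the two is claimed. Compound 3 `CN(C(=O)NC(=O)c1ccccc1F)c1nc(C(F)(F)F)c(C(=O)N/N=C/c2cccc(C(F)(F)F)c2)s1` has not yet been measured in this assay. It differs from compound 2 by 3-(trifluoromethyl)phenyl in place of 2-(trifluoromethyl)phenyl on a carbon with a double bond to nitrogen. Among the measured compounds shown here, no step between measured compounds is available, so nothing recorded bears directly on this change. With the two measured numbers sitting close together, the expected step from compound 2 to compound 3 is a 1.1-fold lower number from compound 2 to compound 3 (0.03 log units; within the scatter), that is, none beyond the scatter. Compound 3 is accordingly estimated at 5 ug/mL in this assay, with a range from 2.5 ug/mL to 10 ug/mL.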

Compound 3, half-maximal inhibitory concentration: 20.3 ug/mL
For compound 3 the middle estimate is 4.1-fold (0.61 log units) below the measured one; measured number above the stated range.
By their numbers in this assay, from the lowest: compounds 1 and 2 (each within the scatter of the next); then compound 3.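

In this assay the same atoms joined differently, 3-(trifluoromethyl)phenyl in place of 2-(trifluoromethyl)phenyl on a carbon with a double bond to nitrogen, give a 3.8-fold higher number from compound 2 to compound 3 (0.58 log units; beyond the scatter) and so show that the place of the trifluoromethyl on this aromatic ring counts in this series, something compounds 1 and 2 could not show while lying within the scatter of each other. Hydrogen in place of trifluoromethyl on an aromatic carbon gives a 4.5-fold higher number from compound 1 to compound 3 (0.66 log units; beyond the scatter) and so ties the lower number of compound 1 to the trifluoromethyl that compound 3 lacks. No measured data on hand bear on the reason for either step.

Still open, going by these compounds, is whether the higher number of compound 3 is particular to trifluoromethyl or also appears with a methoxy group or an amine on the aromatic ring. Also open, on these data alone, is whether these steps keep their size when the rest of the shared core is changed.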